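From Bromo to Trifluoromethyl in a Vanilloid Receptor Antagonist Series

The source may hold more compounds than are shown below. What is called first, only, known or untested is meant among the compounds shown, and "the series" means these compounds.

Within the data shown here, in a functional assay for antagonist activity at transient receptor potential cation channel subfamily V member 1 (Homo sapiens), read by FLIPR and calcium flux (a higher number here means a weaker inhibitor, a lower number a stronger inhibitor), compound 1 `O=C1COc2ccc(NC(=O)C3CCN(c4ccccc4Br)CC3)cc2N1` gives 160 nM, the second highest of the three numbers known. Compound 2 `O=C1COc2ccc(NC(=O)C3CCN(c4cc(F)c(F)c(F)c4)CC3)cc2N1` gives 59 nM, and compound 3 `O=C1COc2ccc(NC(=O)C3CCN(c4cccc(Br)c4)CC3)cc2N1` gives 330 nM. The known steps are a 2.7-fold lower number from compound 1 to compound 2 (0.43 log units; beyond the scatter), a 2.1-fold higher number from compound 1 to compound 3 (0.31 log units; beyond the scatter) and a 5.6-fold higher number from compound 2 to compound 3 (0.75 log units; beyond the scatter). Compound 4 `O=C1COc2ccc(NC(=O)C3CCN(c4ccccc4C(F)(F)F)CC3)cc2N1` differs from compound 1 by trifluoromethyl in place of bromo on an aromatic carbon. Among the measured compounds shown here, no known step exchanges bromo for trifluoromethyl at the same place; compound 2 carries its fluorines as a 3,4,5-trifluorophenyl rather than as trifluoromethyl, so it bears only loosely on this change. The step is therefore expected to be small, near the scatter, in either direction. Compound 4 is expected to give 120 nM, within a range from 50 nM to 300 nM, which amounts to an estimated 1.3-fold lower number from compound 1 to compound 4 (0.12 log units; within the scatter).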

Compound 4, half-maximal inhibitory concentration: 380 nM
Compound 4: the middle estimate sits 3.2-fold (0.50 log units) below what was measured; measured number above the stated range.
By their numbers in this assay, from the lowest: compound 2; then compound 1; then compounds 3 and 4 (each within the scatter of the next).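

In this assay, trifluoromethyl is not a neutral stand-in for bromo on this aromatic carbon: the exchange gives a 2.4-fold higher number from compound 1 to compound 4 (0.38 log units; beyond the scatter), a modest loss that lies beyond the scatter. The 2-(trifluoromethyl)phenyl group cannot be ordered against 3-bromophenyl, at a 1.2-fold higher number from compound 3 to compound 4 (0.06 log units; within the scatter), but it falls well short of 3,4,5-trifluorophenyl, at a 6.4-fold higher number from compound 2 to compound 4 (0.81 log units; beyond the scatter). No measurement at hand explains this loss. Still open, as far as these compounds go, is how chloro, methyl or methoxy would fare in place of bromo here. Also open, from the compounds shown here alone, is whether trifluoromethyl in place of bromo on the 3-bromophenyl ring would give a similar step.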